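The source may hold more compounds than are shown below. What is called first, only, known or untested is meant among the compounds shown, and "the series" means these compounds.

Compound 3, `CCC1(OC(=O)N2CCC(Oc3ncnc(Oc4ccc(S(C)(=O)=O)nc4C)c3F)CC2)CC1`, gives 333 nM in a functional assay on isolated protein for inhibition of Glucose-dependent insulinotropic receptor (Rattus norvegicus), read by HTRF and cAMP accumulation (on this read-out lower numbers stand for an effect already at smaller amounts and higher numbers for an effect only at larger amounts of compound), and so shows the highest number of the three measured here, though with compound 2, `Cc1nc(S(C)(=O)=O)ccc1Oc1ncnc(OC2CCN(C(=O)OC(C)F)CC2)c1F`, at 315 nM, the pair lies within the scatter. Compound 1, `Cc1nc(S(C)(=O)=O)ccc1Oc1ncnc(OC2CCN(C(=O)OC(C)C)CC2)c1F`, gives 142 nM, and the step of a 2.3-fold higher number from compound 1 to compound 3 (0.37 log units; beyond the scatter) separates it from compound 3. Alongside, a 2.2-fold higher number from compound 1 to compound 2 (0.35 log units; beyond the scatter) and a 1.1-fold higher number from compound 2 to compound 3 (0.02 log units; within the scatter) keep the three within a narrow band.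

Compound 4, `Cc1nc(S(C)(=O)=O)ccc1Oc1ncnc(OC2CCN(C(=S)OC(C)C)CC2)c1F`, differs from compound 3 by a group of 6 heavy atoms (4 carbon, 1 oxygen, 1 sulfur; no ring) in place of a group of 8 heavy atoms (6 carbon, 2 oxygen; one three-membered non-aromatic ring of carbon only), on an amine nitrogen in a ring. The change has two parts. The first is the return from the 1-ethylcyclopropyl to the isopropyl carrier seen in compound 1, and the step of a 2.3-fold higher number from compound 1 to compound 3 (0.37 log units; beyond the scatter) suggests that this part alone would bring the number back down by a modest amount. For the measured compounds named here, the second part is the exchange of the carbonyl for a thiocarbonyl in the carbamate, and no measured pair in this set isolates that exchange, so its contribution is unknown. For compound 4 the expected step is a 1.9-fold lower number from compound 3 to compound 4 (0.27 log units; within the scatter). Compound 4 is therefore estimated at 180 nM, within 60 nM to 550 nM.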

Compound 4, half-maximal effective concentration: 1050 nM
Compound 4: the middle estimate sits 5.8-fold (0.77 log units) below what was measured, outside the stated range (above it).
By their numbers in this assay, from the lowest: compound 1; then compounds 2 and 3 (each within the scatter of the next); then compound 4.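

For the compounds shown here, the clearest reading is a 7.4-fold higher number from compound 1 to compound 4 (0.87 log units; beyond the scatter), where the isopropyl group stays and only the carbamate carbonyl becomes a thiocarbonyl; this single exchange gives a larger step than either change of the group on the carbamate oxygen among the earlier compounds. Compound 4 also stands beyond the scatter from the other two carbamates, with a 3.3-fold higher number from compound 2 to compound 4 (0.52 log units; beyond the scatter) and a 3.2-fold higher number from compound 3 to compound 4 (0.50 log units; beyond the scatter), so at this amine nitrogen in a ring the carbonyl matters more in this small set than the three carbamate oxygen groups compared so far. Nothing in the data accounts for this shift.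

The compounds shown carry the thiocarbonyl only with isopropyl, so whether the exchange gives a similar step with 1-fluoroethyl or 1-ethylcyclopropyl stays open. On these data alone, how an amide or a urea on the same nitrogen would read also stays open.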